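The source may report more compounds than this note shows. Statements on the series, on what has been measured and on what is new or still open speak of the compounds shown alone.

Measured in a functional assay on A 172 cells (Homo sapiens) for cytotoxicity, read by colorimetric assay and MTT assay; on this read-out lower numbers stand for stronger inhibition and higher numbers for weaker inhibition:
- Compound 1 `COc1ccc(-c2cc3cccc(OC)c3nc2O)cc1`: 10000 nM
- Compound 2 `CCN(CC)C(=O)Cn1c(=O)c(-c2ccc(OC)cc2)cc2c(OC)cc(OC)cc21`: 10000 nM
- Compound 3 `COc1ccc(-c2cc3c(OC)cc(OC)cc3n(CC(=O)OCc3ccccc3)c2=O)cc1`: 10000 nM

Compound 3 stands level with compound 1 and compound 2, so none of the three separates from the others on these numbers. The next compound, compound 4 `CCN(CC)C(=O)CCn1c(=O)c(-c2ccc(OC)cc2)cc2c(OC)cc(OC)cc21`, differs from compound 3 as follows: (diethylcarbamoyl)methyl in place of benzyloxycarbonyl on a saturated chain carbon bound to an aromatic nitrogen. In plain terms, (diethylcarbamoyl)methyl replaces benzyloxycarbonyl on a saturated chain carbon bound to an aromatic nitrogen.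

Among the measured compounds shown here, only one measured step bears on this change, and it swaps benzyloxy for diethylamino on a carbonyl carbon: no change at the digits printed from compound 2 to compound 3 (within the scatter). That step gives no reason to expect movement in this assay, though it does not test the full change. The estimated step is no change at the digits printed from compound 3 to compound 4 (within the scatter), none beyond the scatter.

For compound 4 the expected value is 10000 nM, with an estimated range of 5000 nM to 20000 nM.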

Compound 4, half-maximal inhibitory concentration: 10000 nM
The estimate for compound 4 equals the measured number at the digits printed, within the range that was stated.
By their numbers in this assay, from the lowest: compounds 1, 2, 3 and 4 (each within the scatter of the next).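

In this assay, the step is no change at the digits printed from compound 3 to compound 4 (within the scatter) when (diethylcarbamoyl)methyl replaces benzyloxycarbonyl on a saturated chain carbon bound to an aromatic nitrogen. Lengthening the chain, with (diethylcarbamoyl)methyl in place of diethylcarbamoyl, gives no change at the digits printed from compound 2 to compound 4 (within the scatter) as well, so this chain length now joins the terminal group as a change that shifts nothing here. No available evidence accounts for this flat result.

Still open, as far as these compounds go, is whether a carboxylic acid or an amine at the end of this chain would separate from these four compounds. From the compounds shown here alone, a longer chain remains equally open.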